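Amino substitution on two benzyl purine cores

The compounds below may be only part of what the source reports. "The series", "measured", "known", "first", "only" and "open" are said of these compounds alone.

Three chloropurine derivatives carrying a chloromethylbenzyl group have been examined in a functional assay on U-251 cells (Homo sapiens) for cytotoxicity, read by sulforhodamine B assay, with a stated time of 48 h; on this read-out higher numbers stand for weaker inhibition of growth and lower numbers for stronger inhibition of growth. Compound 1 `ClCc1ccc(Cn2cnc3c(Cl)ncnc32)cc1` gives 3010 nM. Compound 2 `Nc1nc(Cl)c2ncn(Cc3ccc(CCl)cc3)c2n1` differs from compound 1 by amino in place of hydrogen on an aromatic carbon; in this assay compound 2 gives 12000 nM, and this change produced a 4.0-fold higher number from compound 1 to compound 2 (0.60 log units; beyond the scatter). Compound 3 `ClCc1ccccc1Cn1cnc2c(Cl)ncnc21` gives 6160 nM, and its value stands within the scatter of that of compound 2, so no order between the two is claimed, while it sits beyond the scatter from compound 1. Compound 3 and compound 1 share the same atoms joined differently; the difference between the two cores is not broken down here.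

Compound 4 `Nc1nc(Cl)c2ncn(Cc3ccccc3CCl)c2n1` has not yet been measured in this assay. It differs from compound 3 by amino in place of hydrogen on an aromatic carbon, and the surroundings of that place are described in the same words as for the change from compound 1 to compound 2, so it counts as the same change on a different core.

Among the measured compounds shown here, the expected size of the step is a 3.6-fold higher number from compound 3 to compound 4 (0.55 log units; beyond the scatter), because a 4.0-fold higher number from compound 1 to compound 2 (0.60 log units; beyond the scatter) is the only measured instance of this change and the account rests on it alone. Whether the core of compound 3 carries the change equally is not known from the data. On this basis compound 4 is estimated at 22000 nM, with a plausible range from 9000 nM to 55000 nM.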

Compound 4, concentration for total growth inhibition: 13500 nM
Beside the measured number, compound 4's estimate is 1.6-fold (0.21 log units) above it, within the range that was stated.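

In this assay, amino in place of hydrogen on an aromatic carbon gives a 2.2-fold higher number from compound 3 to compound 4 (0.34 log units; beyond the scatter) and so moves the number in the same direction on the core of compound 3 as on the core of compound 1, with weaker inhibition of growth on both. The gap between the two steps is within the scatter, so they cannot be told apart in size: the same change on two cores in this assay, a 4.0-fold higher number (0.60 log units; beyond the scatter) from compound 1 to compound 2 and a 2.2-fold higher number (0.34 log units; beyond the scatter) from compound 3 to compound 4, 1.8-fold (0.26 log units) apart, within the scatter of two such steps

In this series the change therefore carries from one core to the other, in direction and, as far as the scatter allows, in size. Among the compounds shown here, this rests on only two pairs of compounds in a single cell line, however, and it does not show that the step would hold on any further core, nor does it explain why the numbers move as they do.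

The compounds shown leave open whether another group in the same place, such as methylamino, dimethylamino or hydroxyl, would shift the number as amino does. They also leave open how much the chloromethyl group contributes, as all four compounds carry it and none has a hydroxymethyl or methyl group in its stead.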